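Shrinking the Ring on the Amide Nitrogen

This account rests on a few compounds, and the source may have more. Where it says the series, first, only, none or still open, it means among the compounds named here.

Of the compounds shown here, three have so far been measured in a functional assay on HEp-2 cells (Homo sapiens) for inhibition; on this read-out lower numbers stand for stronger inhibition and higher numbers for weaker inhibition. Compound 1 `CCC(C)C(NC(=O)NO)C(=O)NC(c1ccccc1)c1ccccc1` gives 35800 nM, compound 2 `CCC(C)C(NC(=O)n1nnc2ccccc21)C(=O)NC1CCCCC1` gives 57900 nM, and compound 3 `O=C1NC(c2ccccc2)C(=O)N1Cc1ccccc1` gives 82900 nM. All three numbers point to weak inhibition, and the value of compound 2 sits within the usual scatter of both compound 1 and compound 3, so the three cannot be told apart with confidence on these numbers alone.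

Compound 4 `CCC(C)C(NC(=O)n1nnc2ccccc21)C(=O)NC1CCCC1` has not yet been measured. It differs from compound 2 in a single place: cyclopentyl in place of cyclohexyl on an amide-type nitrogen. For the measured compounds named here, no pair of measured compounds shows a change of this kind, so there is no direct guide to its size. With compound 2 at 57900 nM as the starting point, the expected step to compound 4 is no larger than the scatter, in either direction, a 1.0-fold higher number from compound 2 to compound 4 (0.02 log units; within the scatter). Compound 4 is therefore expected to give about 60000 nM in this assay, with a plausible range from 25000 nM to 140000 nM.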

Compound 4, half-maximal inhibitory concentration: 55700 nM
Estimate against measurement, compound 4: 1.1-fold (0.03 log units) above; the measured number falls inside the stated range.
By their numbers in this assay, from the lowest: compounds 1, 4, 2 and 3 (each within the scatter of the next, the first and the last beyond it).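

In this assay, replacing cyclohexyl with cyclopentyl on an amide-type nitrogen gives a 1.0-fold lower number from compound 2 to compound 4 (0.02 log units; within the scatter), so the two compounds cannot be told apart. For the compounds shown here, this is the first pair in the set that differs in only one place, and it shows that at this position, a six-membered carbon ring and a five-membered one give readings that are indistinguishable in this assay. No supporting data are available that could explain this result. 

Going by these compounds alone, this single step covers only two all-carbon rings, so it cannot show how far this tolerance extends. Whether a phenyl ring, a longer chain such as hexyl, an amine or a carboxylic acid on this nitrogen would shift the number beyond the scatter remains an open question.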